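Benzyl to phenyl on the aminopyrimidine nitrogen

This account rests on a few compounds, and the source may have more. Where it says the series, first, only, none or still open, it means among the compounds named here.

Of the compounds shown here, three have been measured in a functional assay on MDA-MB-231 cells (Homo sapiens) for antiproliferative activity, read by MTT assay, with a stated time of 48 h; a lower number here means a stronger inhibitor, a higher number a weaker inhibitor. Compound 1 `COC(=O)CN(C)c1nc(Nc2cccc(OC)c2)ncc1[N+](=O)[O-]` gives 58000 nM, compound 2 `COC(=O)CN(C)c1nc(NCc2ccccc2)ncc1[N+](=O)[O-]` gives 61100 nM, and compound 3 `CCOC(=O)CN(Cc1ccccc1)c1nc(NCc2ccccc2)ncc1[N+](=O)[O-]` gives 82400 nM. Compound 3 carries the highest of the three numbers, yet its gaps to compound 2 and compound 1 both sit within the scatter. Among the measured compounds shown here, the only single-point step on record, a 1.1-fold higher number from compound 1 to compound 2 (0.02 log units; within the scatter), changed the same nitrogen as the one now in question and moved the number hardly at all. Compound 4 `CCOC(=O)CN(Cc1ccccc1)c1nc(Nc2ccccc2)ncc1[N+](=O)[O-]` differs from compound 3 by phenyl in place of benzyl on a nitrogen on an aromatic ring. Given that precedent, no step beyond the scatter is expected in this assay for compound 4, so the step of a 1.0-fold lower number from compound 3 to compound 4 (0.01 log units; within the scatter) is estimated to be small. Compound 4 is therefore expected to give about 80000 nM, between 40000 nM and 160000 nM.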

Compound 4, half-maximal inhibitory concentration: > 100000 nM
Compound 4 ended at the assay's limit (the forecaster's own chance of this, stated with the estimate: 10%); at least 1.2-fold (0.09 log units) between middle value and limit.
By their numbers in this assay, from the lowest: compounds 1, 2 and 3 (each within the scatter of the next). At a limit, above all of these: compound 4.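

Compound 4 stands at a limit of this assay, not at a number: the limit of > 100000 nM in this assay, at which 1 of the 4 values shown sits. Benzylamino to anilino here gives an at least 1.2-fold higher number from compound 3 to compound 4 (0.08 log units; that floor lies within the scatter), which is only a floor, so the true size of this change on the nitrogen cannot be read. The earlier change at this nitrogen, a 1.1-fold higher number from compound 1 to compound 2 (0.02 log units; within the scatter), had a readable size, whereas this one leaves open whether the step lies beyond the scatter.

Still open, from the compounds shown here alone, is how a carboxylic acid in place of the ester would read in this assay. Going by these compounds, a pyridine in place of the phenyl on this nitrogen is equally open.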